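The source may report more compounds than this note shows. Statements on the series, on what has been measured and on what is new or still open speak of the compounds shown alone.

Compound 1 `O=C(N[C@H]1CCC[C@H](NC(=O)C2CCCCC2)C1)c1cccc(Cl)c1` is one of three measured members of a small series built on a shared core carrying two amide groups. In a functional assay on HEK293 cells for antagonist activity at metabotropic glutamate receptor 5 (Homo sapiens), read by FLIPR and calcium flux (a higher number here means a weaker inhibitor, a lower number a stronger inhibitor), compound 1 gives 857 nM, the higher of the two numbers reported in that assay. Compound 2 `O=C(N[C@@H]1CCC[C@@H](NC(=O)c2ccccn2)C1)c1cccc(Cl)c1`, which carries on the second carbonyl an unsubstituted version of the aromatic ring that enters in the step considered later, gives 62 nM in this assay, a step from compound 1 that lies beyond the usual scatter. Compound 3 `COc1cccc(C(=O)NC2CCCC(NC(=O)c3ccccn3)C2)c1` reaches only the limit of the assay, (the limit of > 10000 nM in this assay, at which 1 of the 3 values shown sits), and in this assay compound 3 gives > 10000 nM. The step considered here leads to compound 4 `Cc1cccc(C(=O)N[C@H]2CCC[C@H](NC(=O)c3cccc(Cl)c3)C2)n1`, which differs from compound 1 in one place: 6-methylpyridin-2-yl in place of cyclohexyl on a carbonyl carbon whose other neighbour is an amide-type nitrogen. For the measured compounds named here, no two measured compounds differ in exactly this way, so the size of the step must be estimated. Because compound 2 gives 62 nM with a closely related aromatic ring in that position, a move toward a lower number is expected, roughly an 11-fold lower number from compound 1 to compound 4 (1.03 log units; beyond the scatter). Compound 4 is therefore estimated at 80 nM in this assay, within 20 nM to 400 nM.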

Compound 4, half-maximal inhibitory concentration: 290 nM
The estimate for compound 4 lay 3.6-fold (0.56 log units) below the measured number, and the stated range covers the measured number.
By their numbers in this assay, from the lowest: compound 2; then compound 4; then compound 1. At a limit, above all of these: compound 3.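

In this assay, for the compounds shown here, this pair gives the first direct reading at this position, on a carbonyl carbon whose other neighbour is an amide-type nitrogen: putting 6-methylpyridin-2-yl in place of cyclohexyl gives a 3.0-fold lower number from compound 1 to compound 4 (0.47 log units; beyond the scatter) and thus a modest gain in inhibition. The earlier compounds shown here could not show this, as no two of them differed in one place only. The result shows that a non-aromatic ring of carbon only is not required here, and that an aromatic ring with one hetero atom and a methyl group gives a stronger inhibitor than cyclohexyl in this pair.

Going by these compounds, this single step changes several things at once, with the ring becoming aromatic and both a ring nitrogen and a methyl group entering, and it remains open which of these accounts for the gain and how a plain phenyl ring, a piperidine ring or a longer alkyl chain would compare on the same carbonyl carbon. Nothing in the data shown bears on why the number falls in this step.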